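Chloro to Fluoro: What Compound 4 Might Show

The compounds below may be only part of what the source reports. "The series", "measured", "known", "first", "only" and "open" are said of these compounds alone.

Three compounds have been tested in a functional assay on the whole organism (strain Swiss) with Mus musculus as the target, in the maximal electroshock model, with a stated time of 0.25 h, at a dose of 300 mg/kg by the intraperitoneal route; on this read-out higher numbers stand for a stronger effect at the one dose given and lower numbers for a weaker effect:

Compound 1, `CC(C(=O)N1CCN(c2ccc(Cl)cc2)CC1)N1C(=O)CCC1=O`, gives 100%.
Compound 2, `CCC(C(=O)N1CCN(c2cccc(OC)c2)CC1)N1C(=O)CCC1=O`, gives 25%.
Compound 3, `CCC(C(=O)N1CCN(c2ccc(C(F)(F)F)cc2)CC1)N1C(=O)CCC1=O`, gives 25%.

Compound 1 stands highest of these three numbers. The nearest to it, compound 2, lies well below, beyond the scatter, and compound 3 lies equally far below.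

Compound 4, `CC(C(=O)N1CCN(c2ccc(F)cc2)CC1)N1C(=O)CCC1=O`, has not yet been measured. It differs from compound 1 in one place: fluoro in place of chloro on an aromatic carbon. Among the compounds with values here, no pair of measured compounds differs in this single place, so no measured step shows what this swap does. A modest fall in this assay is expected, one that could still lie within the scatter: the expected step is a number 25 percentage points lower from compound 1 to compound 4 (beyond the scatter). Compound 4 is estimated at 75%, within a range from 25% to 100%.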

Compound 4, a percentage reported as activity, at one dose (the size of the read-out at that dose, not a potency): 100%
Estimate against measurement, compound 4: 25 percentage points below; low and high end bracket the measured number.
By their numbers in this assay, from the lowest: compounds 2 and 3 (each within the scatter of the next); then compounds 1 and 4 (each within the scatter of the next).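

In this assay, fluoro in place of chloro on an aromatic carbon gives no change at the digits printed from compound 1 to compound 4 (within the scatter) and so shows that this position accepts either group at the one dose given. The read-out comes from a single dose. It says nothing about whether the two compounds match in potency. Nothing shown explains why the two groups give the same number here. Still open, from the compounds shown here alone, is what an amine or a carboxylic acid on this same aromatic carbon would do. Also open, going by these compounds, is whether a hydrogen there, with no halogen at all, would hold the effect.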